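Adding a ring to compound 1 at an aromatic carbon

The source may hold more compounds than are shown below. What is called first, only, known or untested is meant among the compounds shown, and "the series" means these compounds.

The measured compounds:
Compound 1, `CN(Cc1ccc2nccn2c1)c1nnc(-c2ccccc2)o1`, gives 15800 nM in an assay on isolated protein for inhibition of tyrosine-protein kinase Mer (Homo sapiens), read by LC-MS; a lower number here means a stronger inhibitor, a higher number a weaker inhibitor.
Compound 2, `CN(Cc1ccc2nccn2c1)c1nnc(-c2ccc(C3CC3)cc2)o1`, gives 794 nM.
Compound 3, `CN(Cc1ccc2nccn2c1)c1nnc(-c2ccc(-c3ccccc3)cc2)o1`, gives 39.8 nM.

Compound 1 has the highest number of the three, so it is the weakest inhibitor here. Compound 4, `Cc1nn(C)c(C)c1-c1ccc(-c2nnc(N(C)Cc3ccc4nccn4c3)o2)cc1`, is not yet measured. It differs from compound 1 in one place: 1,3,5-trimethyl-1H-pyrazol-4-yl in place of hydrogen on an aromatic carbon.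

Two measured steps start from the same compound and put a group on the same aromatic carbon. The cyclopropyl gave a 20-fold lower number from compound 1 to compound 2 (1.30 log units; beyond the scatter), and the phenyl gave a 400-fold lower number from compound 1 to compound 3 (2.60 log units; beyond the scatter). Comparing the two groups directly, a 20-fold lower number from compound 2 to compound 3 (1.30 log units; beyond the scatter). Every addition at this carbon so far has lowered the number by a large amount, and the aromatic ring lowered it most. The trimethylpyrazolyl entering in compound 4 is also an aromatic ring, so a large step downward in this assay is expected for compound 4, roughly a 160-fold lower number from compound 1 to compound 4 (2.20 log units; beyond the scatter). For compound 4 the estimate is 100 nM, with a range from 20 nM to 500 nM.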

Compound 4, half-maximal inhibitory concentration: 31.6 nM
Compound 4: the middle estimate sits 3.2-fold (0.50 log units) above what was measured; the range from low to high includes it.
By their numbers in this assay, from the lowest: compounds 4 and 3 (each within the scatter of the next); then compound 2; then compound 1.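

In this assay, a five-membered aromatic ring with 2 hetero atoms gives a 500-fold lower number from compound 1 to compound 4 (2.70 log units; beyond the scatter), so at this carbon the large drop is not confined to the all-carbon phenyl ring. Replacing phenyl with 1,3,5-trimethyl-1H-pyrazol-4-yl gives a 1.3-fold lower number from compound 3 to compound 4 (0.10 log units; within the scatter), so the assay does not separate these two quite different aromatic rings. Replacing cyclopropyl with the same group gives a 25-fold lower number from compound 2 to compound 4 (1.40 log units; beyond the scatter), which places compound 4 with compound 3, well apart from compound 2.

Nothing available explains how these rings lower the number. As far as these compounds go, it remains open whether the three methyl groups matter, which a plain pyrazolyl ring would test, and whether a morpholine ring, a carboxylic acid or a longer chain such as n-butyl at this carbon would give a number this low.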